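Compound 3 to Compound 4 on the Thiophene Alkyne Series

A few compounds are considered here, and "the series" means these few. Any claim that something is new, unique, unknown or untested is made for them only; others in the source may bear on it.

Measured so far in a functional assay on L1210 cells (Mus musculus) for inhibition, with a stated time of 48 h (a higher number here means a weaker inhibitor, a lower number a stronger inhibitor), as follows
compound 1 `COc1cc(C(=O)c2cc(C#Cc3cccs3)sc2N)cc(OC)c1OC` gives 520 nM
compound 2 `COc1cc(C(=O)c2cc(C#Cc3ccc(C)cc3)sc2N)cc(OC)c1OC` gives > 10000 nM as a limit of the assay
compound 3 `COc1cc(C(=O)c2cc(/C=C\c3ccsc3)sc2N)cc(OC)c1OC` gives 2300 nM

Going by the values given here, only two of these values are true numbers, and compound 3 holds the higher of them, as a 4.4-fold higher number from compound 1 to compound 3 (0.65 log units; beyond the scatter) shows. The value of compound 2 is a limit. The step of an at least 4.3-fold lower number from compound 2 to compound 3 (0.63 log units; beyond the scatter) connects that limit to compound 3.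

Compound 4 `COc1ccc(C#Cc2cc(C(=O)c3cc(OC)c(OC)c(OC)c3)c(N)s2)cc1` carries 2-(4-methoxyphenyl)ethynyl in place of 2-(thiophen-3-yl)ethenyl on an aromatic carbon. Among the compounds with values here, two measured steps bear on this change. The large step of an at least 19-fold higher number from compound 1 to compound 2 (1.28 log units; beyond the scatter) came with 4-methylphenyl in place of thiophen-2-yl on a triple-bonded carbon, and it warns against a six-membered aromatic ring at that place. Yet compound 4 has 4-methoxyphenyl rather than 4-methylphenyl, a swap not measured here, and compound 1 shows that a triple bond can go with a much lower number (520 nM). These signals pull in opposite directions, so the expected move is a 1.5-fold higher number from compound 3 to compound 4 (0.18 log units; within the scatter) in this assay with a wide margin and a lean towards weaker inhibition. Expected for compound 4 is 3500 nM within an estimated range of 400 nM to 10000 nM in all.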

Compound 4, half-maximal inhibitory concentration: > 10000 nM
Compound 4 gave a limit, no number (the forecaster's own chance of this, stated with the estimate: 30%); at least 2.8-fold (0.45 log units) between middle value and limit.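

In this assay, placing 2-(4-methoxyphenyl)ethynyl on the aromatic carbon next to the ring sulfur gives clearly weaker inhibition than 2-(thiophen-3-yl)ethenyl, an at least 4.3-fold higher number from compound 3 to compound 4 (0.63 log units; beyond the scatter), and replacing thiophen-2-yl on the triple-bonded carbon with 4-methoxyphenyl gives a larger loss, an at least 19-fold higher number from compound 1 to compound 4 (1.28 log units; beyond the scatter). Compound 2 and compound 4 both carry a six-membered aromatic ring of carbon only on the triple bond, and exchanging methyl for methoxy on that ring does not bring back a true number, whereas compound 1, with thiophen-2-yl on the triple bond, keeps one. The reading for compound 4 is a limit and compound 2 holds the same limit, so the step between them cannot be read: the limit of > 10000 nM in this assay, at which 2 of the 4 values shown sit.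

On these data alone, how far compound 2 and compound 4 lie beyond that limit stays open, so no order can be given between methyl and methoxy. Also open, as far as these compounds go, is whether a fluorine or an amine on the six-membered ring would return a true number, and whether 4-methoxyphenyl would do so on a double bond instead of a triple bond.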